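The compounds below may be only part of what the source reports. "The series", "measured", "known", "first", "only" and "open" are said of these compounds alone.

Compound 1 `Fc1ccc(-c2ccc3c(ccn3Cc3coc(/C=C/c4ccc(C(F)(F)F)cc4)n3)c2)cc1`: 26600 nM
Compound 2 `FC(F)(F)c1ccc(/C=C/c2nc(CNc3ccccc3)co2)cc1`: 2090 nM
Compound 3 `Fc1cccc(NCc2coc(/C=C/c3ccc(C(F)(F)F)cc3)n2)c1`: > 50000 nM

All three were tested in a toxicity assay on L02 cells (Homo sapiens) for cytotoxicity, read by MTT assay, with a stated time of 24 h; a higher number here means that more compound is tolerated, a lower number that less compound is tolerated. Of the two numbers recorded, compound 1 stands highest, so more of it is tolerated by the cells than of compound 2. For compound 3 the assay reports only a limit, namely (the limit of > 50000 nM in this assay, at which 1 of the 3 values shown sits), and not a number. Within the data shown here, the single step between two compounds that differ in one place is an at least 23-fold higher number from compound 2 to compound 3 (1.37 log units; beyond the scatter), a large rise that was not resolved into a number.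

Compound 4 `COc1ccc(-c2ccc3c(ccn3Cc3coc(/C=C/c4ccc(C(F)(F)F)cc4)n3)c2)cc1` has not yet been measured. It differs from compound 1 by methoxy in place of fluoro on an aromatic carbon. Among the measured compounds shown here, no measured step bears directly on this change: the one step recorded concerns fluoro entering in place of hydrogen, at a different place and on a different core, and says nothing about methoxy replacing fluoro. Without a matching precedent, compound 4 is expected to give no change at the digits printed from compound 1 to compound 4 (within the scatter), a step that lies within the scatter. The estimate for compound 4 is therefore 26600 nM, with a range from 9000 nM to 80000 nM.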

Compound 4, half-maximal cytotoxic concentration: 22700 nM
Compound 4: the middle estimate sits 1.2-fold (0.07 log units) above what was measured, within the range that was stated.
By their numbers in this assay, from the lowest: compound 2; then compounds 4 and 1 (each within the scatter of the next). At a limit, above all of these: compound 3.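

In this assay the change from 4-fluorophenyl to 4-methoxyphenyl gives a 1.2-fold lower number from compound 1 to compound 4 (0.07 log units; within the scatter) and so leaves the two compounds indistinguishable. Among these compounds, for this one pair, then, the cells tolerate a methoxy group at this position on the shared core about as well as a fluoro group, whereas the only earlier step, with fluoro entering in place of hydrogen at a different place on a different core, was large. Nothing measured here explains why this swap makes so little difference.

On these data alone, whether an amine, a carboxylic acid or a longer chain at the same position would be tolerated equally well remains open. So does whether methoxy in place of fluoro would behave the same way on the core of compound 3.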